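Methoxy on the benzyl group: compound 2 to compound 3

The compounds below may be only part of what the source reports. "The series", "measured", "known", "first", "only" and "open" are said of these compounds alone.

Going by the values given here, in a functional assay on PC-3 cells (Homo sapiens) for inhibition, read by MTT assay, with a stated time of 72 h (a higher number here means a weaker inhibitor, a lower number a stronger inhibitor), compound 2 `CC(C)n1ncc2c(C(=O)NCc3cn(Cc4ccccc4)nn3)cccc21` gives 4420 nM, the lowest of the two numbers so far; compound 1 `Cc1cccc(-n2cc(CNC(=O)c3cccc4c3cnn4C(C)C)nn2)c1` gives 32300 nM. Among the compounds with values here, the one measured step, a 7.3-fold lower number from compound 1 to compound 2 (0.86 log units; beyond the scatter), is a benzyl in place of 3-methylphenyl on an aromatic nitrogen. Compound 3 `COc1ccc(Cn2cc(CNC(=O)c3cccc4c3cnn4C(C)C)nn2)cc1` keeps the benzyl and differs from compound 2 only by methoxy in place of hydrogen on an aromatic carbon, placed on an aromatic carbon of a six-membered aromatic ring of carbon only, para to a large group. Within the data shown here, no measured step adds a methoxy to that ring, and the only step on record exchanges the whole aryl group rather than a substituent on it, so it bears on compound 3 only loosely. The change is expected to give a step no larger than the scatter, a 1.3-fold lower number from compound 2 to compound 3 (0.10 log units; within the scatter), leaning if anything toward a lower number. Compound 3 is therefore expected at 3500 nM, within 1200 nM to 10000 nM.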

Compound 3, half-maximal inhibitory concentration: 34000 nM
Estimate against measurement, compound 3: 9.7-fold (0.99 log units) below; the measured number lies above the stated range.
By their numbers in this assay, from the lowest: compound 2; then compounds 1 and 3 (each within the scatter of the next).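

In this assay, the aromatic ring of the benzyl group in compound 2 does not tolerate every substituent: methoxy in place of hydrogen, para to a large group, gives a 7.7-fold higher number from compound 2 to compound 3 (0.89 log units; beyond the scatter). Benzyl in place of 3-methylphenyl is therefore not enough on its own to hold the lower number, since 4-methoxybenzyl in place of 3-methylphenyl gives a 1.1-fold higher number from compound 1 to compound 3 (0.02 log units; within the scatter), and among these compounds only the unsubstituted benzyl of compound 2 stands apart. Nothing at hand explains the size of the methoxy step.

On these data alone, whether this step belongs to methoxy itself or to any substituent at this place remains open. Fluoro, hydroxy or dimethylamino at the same place on the benzyl ring would separate these two readings.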